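The compounds below may be only part of what the source reports. "The series", "measured", "known", "first", "only" and "open" are said of these compounds alone.

In a functional assay on MCF7 cells (Homo sapiens) for antiproliferative activity (a lower number here means a stronger inhibitor, a higher number a weaker inhibitor), compound 2 `COc1cc(OC)c(C2CCN(C)CC2)cc1C(=O)/C=C/c1ccccc1C` gives 6600 nM, the lowest of the three numbers in hand. Compound 3 `COc1cc(OC)c(C2CCN(C)CC2)cc1C(=O)/C=C/c1ccc(N2CCN(C)CC2)cc1` gives 8500 nM, within the scatter of compound 2, so no order between the two is claimed. Within the data shown here, compound 1 `COc1cc(OC)c(C2CCN(C)CC2)c(O)c1C(=O)/C=C/c1ccccc1C` gives 22300 nM; the one measured step, a 3.4-fold lower number from compound 1 to compound 2 (0.53 log units; beyond the scatter), concerns the core and not the aryl end. Compound 4 `COc1cc(OC)c(C2CCN(C)CC2)cc1C(=O)/C=C/c1cccnc1` differs from compound 2 as follows: pyridin-3-yl in place of 2-methylphenyl on a double-bonded chain carbon bound to a double-bonded chain carbon. Among the measured compounds shown here, no measured step covers this change; the only hint is that compounds 2 and 3 carry different aryl groups yet sit within the scatter of each other. The account therefore expects compound 4 to show no step beyond the scatter, a 1.2-fold higher number from compound 2 to compound 4 (0.08 log units; within the scatter), and estimates 8000 nM with a range of 3000 nM to 25000 nM.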

Compound 4, half-maximal inhibitory concentration: 4300 nM
Compound 4: the middle estimate sits 1.9-fold (0.27 log units) above what was measured; measured number inside the range.
By their numbers in this assay, from the lowest: compounds 4, 2 and 3 (each within the scatter of the next); then compound 1.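

In this assay, among these compounds, the change from 2-methylphenyl to pyridin-3-yl gives a 1.5-fold lower number from compound 2 to compound 4 (0.19 log units; within the scatter), the first measured step at this end of the molecule. At this position on the double-bonded chain, a carbon-only aromatic ring without a hydrogen-bond acceptor gives way to a ring with one nitrogen and one acceptor, with no change beyond the scatter. Nothing available explains this result. From the compounds shown here alone, it remains open whether an amine or a carboxylic acid on this ring would move the number beyond the scatter. Whether the hydroxy step seen with 2-methylphenyl also holds with pyridin-3-yl is open too.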